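Lengthening the sulfur chain of compound 2

The source may hold more compounds than are shown below. What is called first, only, known or untested is meant among the compounds shown, and "the series" means these compounds.

Values in a functional assay on MT4 cells (Homo sapiens) for cytotoxicity; on this read-out lower numbers stand for higher toxicity in this test and higher numbers for lower toxicity in this test:
- compound 1 `CC(C)Sc1nc(O)cc(C(C)c2cccc3ccccc23)n1`: 119000 nM
- compound 2 `CSc1nc(O)cc(C(C)c2c(F)cccc2F)n1`: 20800 nM

Compound 2, at 20800 nM, holds the lower of the two numbers, and the gap to compound 1 lies beyond the scatter. Compound 3 `CC(C)CSc1nc(O)cc(C(C)c2c(F)cccc2F)n1` carries isopropyl in place of hydrogen on a saturated chain carbon bound to a sulfur. For the measured compounds named here, no measured pair isolates this change. The expected 1.8-fold higher number from compound 2 to compound 3 (0.26 log units; within the scatter) stays within the scatter, leaning upward in this assay. That lean rests only on compound 1 at 119000 nM, which differs from compound 2 in more than one place. For compound 3 the estimated value is 38000 nM, with an expected range of 13000 nM to 110000 nM.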

Compound 3, half-maximal cytotoxic concentration: > 200000 nM
Compound 3 gave a limit, no number (the forecaster's own chance of this, stated with the estimate: 25%); middle value at least 5.2-fold (0.72 log units) away from the limit.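

In this assay compound 3 gives > 200000 nM, which is a limit and not a number. Replacing methylsulfanyl with isobutylsulfanyl gives an at least 9.6-fold higher number from compound 2 to compound 3 (0.98 log units; beyond the scatter), so a single change on the saturated chain carbon bound to the sulfur is now seen to move this read-out beyond the scatter. The full size of the step stays undefined, and the limit marks the top of what is readable here: the limit of > 200000 nM in this assay, at which 1 of the 3 values shown sits.

As far as these compounds go, how an ethyl chain, or a sulfur chain ending in an amine, would read in this assay remains open. Also open, from the compounds shown here alone, is whether the same change carries over to the rest of the structure of compound 1.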